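This account rests on a few compounds, and the source may have more. Where it says the series, first, only, none or still open, it means among the compounds named here.

Of the compounds shown here, three have been measured in a functional assay on DU-145 cells (Homo sapiens) for cytotoxicity, read by trypan blue exclusion, with a stated time of 96 h; on this read-out lower numbers stand for stronger inhibition and higher numbers for weaker inhibition. Compound 1 `COc1ccc(/C=C/S(=O)(=O)Nc2c(F)c(F)c(F)c(F)c2F)cc1N` gives 35000 nM, compound 2 `COc1ccc(NS(=O)(=O)/C=C/c2c(OC)cc(OCCCC(=O)O)cc2OC)cc1O` gives 10000 nM, and compound 3 `COC(=O)CNc1cc(NS(=O)(=O)/C=C/c2c(OC)cc(OC)cc2OC)ccc1OC` gives 350 nM. Compound 3 thus stands at the lowest number of the three: the nearest of the others is compound 2, whose number is beyond the scatter of this assay, and the furthest is compound 1, whose number lies further still. No two of these compounds differ in only one place, so the account of what changed rests on the pair of compound 3 and compound 4 alone.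

Compound 4 `COc1cc(OC)c(/C=C/S(=O)(=O)Nc2ccc(OC)c(NC(C(=O)O)c3ccc(Br)cc3)c2)c(OC)c1` has not yet been measured. It differs from compound 3 in one place: (4-bromophenyl)(carboxy)methyl in place of (methoxycarbonyl)methyl on a nitrogen on an aromatic ring. A larger group enters on the nitrogen, bringing one hydrogen-bond donor in place of two acceptors, and the piece of the molecule that stays the same is the whole of the rest of compound 3.

Without a measured step of this kind to lean on, the expected step in this assay from compound 3 to compound 4 is a 2.6-fold higher number from compound 3 to compound 4 (0.41 log units; beyond the scatter), a modest rise in the number that may not reach beyond the scatter. Compound 4 is therefore expected to give about 900 nM in this assay, somewhere between 200 nM and 4000 nM.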

Compound 4, half-maximal inhibitory concentration: 250 nM
For compound 4 the middle estimate is 3.6-fold (0.56 log units) above the measured one, and the stated range covers the measured number.
By their numbers in this assay, from the lowest: compounds 4 and 3 (each within the scatter of the next); then compound 2; then compound 1.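

In this assay, within the data shown here, the exchange on the nitrogen gives a 1.4-fold lower number from compound 3 to compound 4 (0.15 log units; within the scatter) and so, for the first time, a single change can be read. At this place on the aromatic ring, the (methoxycarbonyl)methyl group can give way to the larger (4-bromophenyl)(carboxy)methyl group, which brings a six-membered aromatic ring and a bromine, with no step beyond the scatter. Nothing given here bears on why compound 3 and compound 4 read alike.

Among these compounds, the bromophenyl ring and the carboxy group enter together, so the single step cannot show what either contributes alone, and it leaves open how a carboxymethyl group on the same nitrogen, with the ring absent, or a (4-bromophenyl)(methoxycarbonyl)methyl group, with the carboxylic acid replaced by its methyl ester, would read. Also open, going by these compounds, is whether the bromine matters, which a plain phenyl ring or a 4-chlorophenyl ring in its place would test, and whether an amine or a longer chain on this nitrogen would fit as readily.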